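Benzyl to ethyl on the shared core: expectation

The source may report more compounds than this note shows. Statements on the series, on what has been measured and on what is new or still open speak of the compounds shown alone.

Measured compounds:
compound 1 `CN1CCN(CCNC(=O)n2c(=O)n(Cc3ccccc3)c3ccccc32)CC1` — < 6
compound 2 `CN1CCN(CNC(=O)n2c(=O)n(C3CC3)c3ccccc32)CC1` — 6.19
compound 3 `CC(C)n1c(=O)n(C(=O)NN2CCN(C)CC2)c2ccccc21` — < 6

In a functional assay for antagonist activity at 5-hydroxytryptamine receptor 4 (Cavia porcellus) (a lower number here means a less potent compound, a higher number a more potent compound, by a factor of ten per unit of this negative logarithm), compound 1 gives < 6, which is a limit of the assay and not a number. Compound 3 likewise gives only a limit in this assay, < 6. Compound 2 gives 6.19 in this assay. Among the compounds with values here, compound 1 thus stands at the edge of what this assay resolves, a position it shares with compound 3 (the limit of < 6 in this assay, at which 2 of the 3 values shown sit); no steps between the three measured compounds can be set against each other, since each pair differs in more than one place.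

Compound 4 `CCn1c(=O)n(C(=O)NCCN2CCN(C)CC2)c2ccccc21` differs from compound 1 in one place: methyl in place of phenyl on a saturated chain carbon bound to an aromatic nitrogen. Read one bond further out, the change is benzyl to ethyl on the core of compound 1. Within the data shown here, no measured pair shows this change, so its size is not known from the data. Compound 2 and compound 3, both carrying a small alkyl group on the same nitrogen, give values at or near the limit, and compound 4 is therefore expected to sit in the same region, with a step of a number no lower from compound 1 to compound 4 (the limit leaves the size open) that cannot be told from scatter given that compound 1 is only a limit. Compound 4 is estimated at 6 in this assay, with a range from 5.4 to 6.6, and a real chance that only a limit is returned.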

Compound 4, negative logarithm of the antagonist equilibrium constant: 6.79
Compound 4: middle estimate off by 0.79 log units, on the low side, outside the stated range (above it).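

In this assay compound 1 gives < 6, which is a limit and not a number. Benzyl to ethyl on the shared core, methyl in place of phenyl on a saturated chain carbon bound to an aromatic nitrogen, gives a number at least 0.79 log units higher from compound 1 to compound 4 (beyond the scatter), the first step in the series that can be read and the first sign that the group at this position matters in this assay. The step gives only a floor for the change, and its full size stays unknown because one end of it rests on a limit: the limit of < 6 in this assay, at which 2 of the 4 values shown sit.

Compound 2 and compound 3 differ from compound 4 in more than one place, so they do not show whether the gain belongs to ethyl itself or would hold for other small alkyl groups on this side chain. From the compounds shown here alone, how a propyl group, a longer chain ending in a methoxy group or an amine at this position would compare with compound 4 remains open, and so does the question of whether a chain carbon is needed there at all.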